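Replacing Azepane with Dimethylmorpholine on the Urea Carbonyl

The source may hold more compounds than are shown below. What is called first, only, known or untested is meant among the compounds shown, and "the series" means these compounds.

Three compounds share one core and differ only in the group on the carbonyl carbon. Compound 1 `CC1CCCC(C(=O)N2CC(c3nc(-c4cccc(Cl)c4)no3)C2)C1` carries a 3-methylcyclohexyl group, and in an assay on HEK293 cells for positive allosteric modulation of metabotropic glutamate receptor 5 (Homo sapiens), read by FLIPR (a lower number here means that less compound is needed, a higher number that more compound is needed for the effect), compound 1 gives 410 nM. Compound 2 `O=C(C1CCC1)N1CC(c2nc(-c3cccc(Cl)c3)no2)C1` carries a cyclobutyl group; in this assay compound 2 gives > 10000 nM, which is a limit of the assay and not a number (the limit of > 10000 nM in this assay, at which 1 of the 3 values shown sits). Compound 3 `O=C(N1CCCCCC1)N1CC(c2nc(-c3cccc(Cl)c3)no2)C1` carries an azepan-1-yl group, and in this assay compound 3 gives 47 nM, the lowest of the two numbers shown, with compound 1 as its nearest neighbour.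

Compound 4 `CC1CN(C(=O)N2CC(c3nc(-c4cccc(Cl)c4)no3)C2)CC(C)O1` differs from compound 3 in one place: 2,6-dimethylmorpholin-4-yl in place of azepan-1-yl on a carbonyl carbon. Going by the values given here, two measured steps bear on this position. The step of an 8.7-fold lower number from compound 1 to compound 3 (0.94 log units; beyond the scatter) shows that exchanging the carbonyl substituent can move the value by a modest amount, and the step of an at least 210-fold lower number from compound 2 to compound 3 (2.32 log units; beyond the scatter) shows that a large movement is possible. Compound 4 keeps a ring on the carbonyl carbon of comparable size to that of compound 3, so a modest step is expected, in the direction of a higher number. For compound 4 the expected value in this assay is 150 nM, with a range from 40 nM to 800 nM. The step this estimate implies is expected to be a 3.2-fold higher number from compound 3 to compound 4 (0.50 log units; beyond the scatter).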

Compound 4, half-maximal effective concentration: > 10000 nM
Compound 4 ended at the assay's limit; the forecaster's own chance of this, stated with the estimate: 10%; middle value at least 66-fold (1.82 log units) from the limit.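

In this assay compound 4 gives > 10000 nM, which is a limit of the assay and not a number, and compound 2 stands at the same limit: the limit of > 10000 nM in this assay, at which 2 of the 4 values shown sit.

Although both groups are non-aromatic rings bound through nitrogen to the carbonyl carbon, the exchange of azepan-1-yl for 2,6-dimethylmorpholin-4-yl gives an at least 210-fold higher number from compound 3 to compound 4 (2.32 log units; beyond the scatter), and the exchange of 3-methylcyclohexyl for the same group gives an at least 24-fold higher number from compound 1 to compound 4 (1.38 log units; beyond the scatter). Among the earlier compounds only the cyclobutyl group of compound 2 reached this limit, so compound 4 shows that a six-membered ring at this position can reach it too, and that a large ring on the carbonyl carbon does not by itself keep the value low; the step between compound 2 and compound 4 cannot be read, as both values are limits.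

This single change alters the ring size, adds a ring oxygen and adds two methyl groups at once, and the compounds shown do not separate these three differences. A piperidin-1-yl or an unsubstituted morpholin-4-yl group on the same carbonyl carbon would bear directly on that open question.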